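Series notes: 1H-pyrrol-3-yl in place of 3-methylfuran-2-yl

A few compounds are considered here, and "the series" means these few. Any claim that something is new, unique, unknown or untested is made for them only; others in the source may bear on it.

Three compounds of the series have numbers in a physicochemical assay for solubility, read by mass spectrometry, in phosphate buffer, with a stated time of 24 h, at pH 7.4; on this read-out lower numbers stand for lower solubility and higher numbers for higher solubility. Compound 1 `Cc1ccoc1C(=O)N1CCC(NC(=O)Nc2ccc(C(F)(F)F)cc2)CC1` gives 0.8 ug/mL in this assay. Compound 2 `O=C(Nc1ccc(C(F)(F)F)c(F)c1)NC1CCN(C(=O)C2CC2)CC1` gives 0.46 ug/mL, which lies within the usual scatter of the number for compound 1, so no order between these two is claimed. Compound 3 `O=C(Nc1ccc(OC(F)(F)F)c(F)c1)NC1CCN(C(=O)C2(C(F)(F)F)CC2)CC1` gives 92 ug/mL, a number beyond the scatter and above that of compound 1; compound 1 thus sits second highest of the three. Among the compounds with values here, compound 2 and compound 3 each differ from compound 1 in several places at once, so no single step is defined between them.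

Compound 4 `O=C(Nc1ccc(C(F)(F)F)cc1)NC1CCN(C(=O)c2cc[nH]c2)CC1` is not yet measured. It differs from compound 1 in one place: 1H-pyrrol-3-yl in place of 3-methylfuran-2-yl on a carbonyl carbon. Within the data shown here, no measured pair isolates this kind of change, so any expectation rests on the change alone: the leaving group carries 1 hydrogen-bond acceptor and 0 donors, the entering group 1 hydrogen-bond donor and 0 acceptors. A modest upward step is expected, a 3.8-fold higher number from compound 1 to compound 4 (0.57 log units; beyond the scatter), with no certainty that it clears the scatter. Compound 4 is accordingly estimated at 3 ug/mL, in a range from 0.8 ug/mL to 12 ug/mL.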

Compound 4, solubility: 1.8 ug/mL
The estimate for compound 4 lay 1.7-fold (0.22 log units) above the measured number; low and high end bracket the measured number.
By their numbers in this assay, from the lowest: compounds 2 and 1 (each within the scatter of the next); then compound 4; then compound 3.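

This position, on a carbonyl carbon whose other neighbour is an amide-type nitrogen in a ring, now has its first single-place step: in this assay, 1H-pyrrol-3-yl in place of 3-methylfuran-2-yl gives a 2.3-fold higher number from compound 1 to compound 4 (0.35 log units; beyond the scatter). The earlier compounds shown here differ from one another in several places at once, so none of their differences could be tied to this position alone. No measurement at hand accounts for the step.

The change alters the ring hetero atom, the methyl group and the point of attachment together, and the compounds shown do not separate these. Also open, as far as these compounds go, is how the number responds to other groups at this carbonyl carbon, such as a 3-methyl-1H-pyrrol-2-yl ring or a ring carrying an amine or a carboxylic acid.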